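Replacing an Amine Side Group with a Carbon Chain

The source may hold more compounds than are shown below. What is called first, only, known or untested is meant among the compounds shown, and "the series" means these compounds.

Of the compounds shown here, two have numbers so far in an in vitro ADME assay on microsomes (Rattus norvegicus) for metabolic stability; a lower number here means that the compound disappears faster, a higher number that the compound lasts longer. Compound 1 `CCc1nc(NC(CC)CC)c(OC)nc1-c1ccc(OC(F)F)cc1Cl` gives 0.783 h. Compound 2 `CCc1nc(-c2ccc(Cl)cc2Cl)c(CC)nc1NC(C1CC1)C1CC1` gives 0.0417 h, the lower of the two numbers, and the gap between them lies beyond the usual scatter of repeated measurements. These two compounds differ in more than one place, so their gap cannot be pinned on any single group.

Compound 3 `CCc1nc(-c2ccc(Cl)cc2Cl)c(CC)nc1CC(CC)CC` changes compound 2 in one place, on an aromatic carbon: 2-ethylbutyl stands in place of (dicyclopropylmethyl)amino (2-ethylbutyl in place of (dicyclopropylmethyl)amino on an aromatic carbon). Among the measured compounds shown here, no measured pair shows what such a swap does in this assay, so any forecast here is uncertain. The 2,4-dichlorophenyl group and both ethyl groups stay as they are, so the best anchor is compound 2 at 0.0417 h. The estimated step of a 1.4-fold higher number from compound 2 to compound 3 (0.16 log units; within the scatter) is expected to be small and upward, and it may well stay within the scatter. For compound 3 the expected half-life is estimated at 0.06 h, with a range of 0.025 h to 0.2 h.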

Compound 3, half-life: 0.0417 h
Beside the measured number, compound 3's estimate is 1.4-fold (0.16 log units) above it, and the stated range covers the measured number.
By their numbers in this assay, from the lowest: compounds 2 and 3 (each within the scatter of the next); then compound 1.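

Among the compounds shown here, putting 2-ethylbutyl in place of (dicyclopropylmethyl)amino on this aromatic carbon gives no change at the digits printed from compound 2 to compound 3 (within the scatter) in this assay, and this is the only comparison here in which a single place changes. At this position, the half-life therefore does not separate the two side groups, even though the swap removes the amine nitrogen, with its hydrogen-bond donor and acceptor, as well as both three-membered rings, and leaves an open carbon chain. Nothing available explains why these different groups give readings within the scatter of each other, so the result records an outcome and not a cause.

One side-group swap cannot show whether this position can influence the half-life at all, so a carboxylic acid, an amide or a chain carrying a hydroxyl group on the same aromatic carbon would test that more widely. From the compounds shown here alone, it also remains open whether 2-ethylbutyl and (dicyclopropylmethyl)amino would again read alike with other groups elsewhere on the core, such as a different aryl group in place of 2,4-dichlorophenyl.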